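A Dinitrophenyl Replaces the Dichlorophenyl on Compound 2

The compounds below may be only part of what the source reports. "The series", "measured", "known", "first", "only" and "open" are said of these compounds alone.

Within the data shown here, compound 2 `N#CC1=C(N)Oc2c(N)cc3nc4ccccc4nc3c2C12C(=O)N(Cc1cnnn1-c1cc(Cl)ccc1Cl)c1ccccc12` is the only compound here with a number of its own in a functional assay on MCF7 cells (Homo sapiens) for antiproliferative activity, read by MTT assay, with a stated time of 48 h (a lower number here means a stronger inhibitor, a higher number a weaker inhibitor), where compound 2 gives 33200 nM. Compound 1 `COc1ccc(-n2nncc2CN2C(=O)C3(C(C#N)=C(N)Oc4c(N)cc5nc6ccccc6nc5c43)c3ccccc32)cc1` returns no number in this assay: compound 1 gives > 50000 nM, which is a limit of the assay rather than a measured value. The step from compound 1 to compound 2 is an at least 1.5-fold lower number from compound 1 to compound 2 (0.17 log units; that floor lies within the scatter); it rests on the limit of > 50000 nM in this assay, at which 1 of the 2 values shown sits, and therefore cannot be read as a real change in potency.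

Compound 3 `N#CC1=C(N)Oc2c(N)cc3nc4ccccc4nc3c2C12C(=O)N(Cc1cnnn1-c1ccc([N+](=O)[O-])cc1[N+](=O)[O-])c1ccccc12` differs from compound 2 in one place: 2,4-dinitrophenyl in place of 2,5-dichlorophenyl on an aromatic nitrogen. Among the measured compounds shown here, the only measured step that touches this position is the one from compound 1 to compound 2, which exchanged one aryl group on the aromatic nitrogen for another and showed no movement beyond the scatter. Nothing in the numbers at hand points to a shift beyond the scatter for this new exchange. Compound 3 is therefore expected to give 38000 nM in this assay, with a range from 15000 nM to 95000 nM. The expected step is a 1.1-fold higher number from compound 2 to compound 3 (0.06 log units; within the scatter).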

Compound 3, half-maximal inhibitory concentration: 20900 nM
For compound 3 the middle estimate is 1.8-fold (0.26 log units) above the measured one, within the range that was stated.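

In this assay, the exchange of 2,5-dichlorophenyl for 2,4-dinitrophenyl on the aromatic nitrogen gives a 1.6-fold lower number from compound 2 to compound 3 (0.20 log units; within the scatter), so compound 2 and compound 3 cannot be told apart, even though the two aryl groups differ in their substituents and in their count of hydrogen-bond acceptors. Among these compounds, what the earlier compounds did not show is a step at this position that clears the scatter: replacing 4-methoxyphenyl with 2,4-dinitrophenyl gives an at least 2.3-fold lower number from compound 1 to compound 3 (0.37 log units; beyond the scatter). This step is only a floor, and its true size remains unknown: the limit of > 50000 nM in this assay, at which 1 of the 3 values shown sits.

The compounds shown leave open whether any step at this position would be larger if the aryl group carried an amine or a carboxylic acid, or if a benzyl group or a short alkyl chain took its place on the aromatic nitrogen. They also leave open how far the number for the 4-methoxyphenyl compound lies from those of the two other compounds, and whether the dichloro and dinitro substitution patterns matter separately from one another.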